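Methyl for chlorine on the acid-bearing ring

A few compounds are considered here, and "the series" means these few. Any claim that something is new, unique, unknown or untested is made for them only; others in the source may bear on it.

Compound 1 `Cc1c(OCCCCOc2ccc(C(=O)O)cc2Cl)ccc(C(=O)CC2CCCC2)c1O` was tested in an ADME assay (liver) for metabolic stability, with Liver microsome (Rattus norvegicus) as the target, read by LC-MS, using microsomes and NADPH, with stated times of 5 min and 60 min, tested at 4 uM (a higher number here means that more of the compound is left, a lower number that less of the compound is left), and gives 21%. Compound 2 `CCC(=O)c1ccc(OCCCCOc2ccc(F)c(C(=O)O)c2)c(C)c1O` gives 35% in this assay. Of these two numbers, compound 1 stands lowest, and the gap to compound 2 lies beyond the usual scatter of this measurement, so less of compound 1 is left after the incubation than of compound 2.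

Compound 3 `Cc1cc(OCCCCOc2ccc(C(=O)CC3CCCC3)c(O)c2C)ccc1C(=O)O` has not yet been measured. It differs from compound 1 in one place: 4-carboxy-3-methylphenyl in place of 4-carboxy-2-chlorophenyl on an oxygen on a saturated carbon. The rest of the molecule, including the cyclopentyl-bearing ketone and the four-carbon linker, is unchanged.

For the measured compounds named here, no measured pair shows what such a swap does in this assay, so the expectation rests on compound 1 alone. The change is small in atom count, and the step from compound 1 to compound 3 is expected to be a number 1 percentage points lower from compound 1 to compound 3 (within the scatter), that is, not beyond the scatter in either direction. Compound 3 is therefore estimated to give 20%, with a range from 8% to 38%, because compound 1 gives 21%.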

Compound 3, percent of the compound remaining: 55%
Compound 3: middle estimate off by 35 percentage points, on the low side, and the stated range ends below it.
By their numbers in this assay, from the lowest: compound 1; then compound 2; then compound 3.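

Exchanging 4-carboxy-2-chlorophenyl for 4-carboxy-3-methylphenyl on the oxygen at the end of the four-carbon linker gives a number 34 percentage points higher from compound 1 to compound 3 (beyond the scatter) in this assay. The earlier compounds shown here could not show this, as no measured pair isolated a single change, and it establishes that the acid-bearing ring can strongly affect how much compound remains even with the cyclopentyl-bearing ketone and the linker held fixed. The two groups have the same heavy-atom, donor and acceptor counts and no net charge, so these simple counts give no warning of a step this large, and nothing measured here explains why the number moves.

This single step changes two things at once, removing the chlorine and adding a methyl at a differently numbered place on the ring, so it cannot say how much each contributes. Still open, from the compounds shown here alone, is how the shared core would fare with a plain 4-carboxyphenyl group, with 4-carboxy-2-methylphenyl, which would keep the methyl at the place the chlorine held, or with a methoxy group or a bromine on that ring.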